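A Fluorine Enters the Aryl Ring: Solubility Outlook

A few compounds are considered here, and "the series" means these few. Any claim that something is new, unique, unknown or untested is made for them only; others in the source may bear on it.

Among the compounds with values here, compound 2, `CC(C)OC(=O)N1CCC2(CC1)CC(CCCOc1ccc(S(C)(=O)=O)cc1)C2`, is the one member of this set with an actual number in a physicochemical assay for solubility, read by HPLC, in phosphate buffer, with a stated time of 24 h, at pH 6.8; on this read-out higher numbers stand for higher solubility and lower numbers for lower solubility: in that assay compound 2 gives 0.17 ug/mL. Its neighbour compound 1, `CC(C)(C)OC(=O)N1CCC2(CC1)CC(CCCOc1ccc(S(C)(=O)=O)cc1)C2`, differs only in the alkyl part of the carbamate. In this assay compound 1 returns < 0.13 ug/mL, which is a limit of the assay and not a number. Within the data shown here, the only measured step, an at least 1.3-fold higher number from compound 1 to compound 2 (0.11 log units; that floor lies within the scatter), therefore rests on the limit of < 0.13 ug/mL in this assay, at which 1 of the 2 values shown sits, at one end, and its floor lies within the scatter.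

Compound 3, `CC(C)OC(=O)N1CCC2(CC1)CC(CCCOc1ccc(S(C)(=O)=O)c(F)c1)C2`, arises from compound 2 by fluoro in place of hydrogen on an aromatic carbon. Among the measured compounds shown here, no measured step touches the aromatic ring, so that single step carries no information on this change, and no shift beyond the scatter is expected in this assay. The expected step of no change at the digits printed from compound 2 to compound 3 (within the scatter) is accordingly taken as flat. Compound 3 is estimated at 0.17 ug/mL, with a range from 0.08 ug/mL to 0.4 ug/mL, and with a real chance that the assay reports only a limit.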

Compound 3, solubility: < 0.16 ug/mL
Compound 3: no number, only a limit (the forecaster's own chance of this, stated with the estimate: 35%); at least 1.0-fold (0.02 log units) between middle value and limit.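

Fluoro in place of hydrogen on an aromatic carbon, ortho to a methylsulfonyl group, gives the first reading on the aromatic ring in this set, since the earlier step changed only the alkyl part of the carbamate: it amounts to an at least 1.0-fold lower number from compound 2 to compound 3 (0.02 log units; that floor lies within the scatter) in this assay. In this assay compound 3 gives < 0.16 ug/mL, which is a limit of the assay and not a number. The step therefore has only a floor, shows no shift beyond the scatter and gives no size for this change, and the reading rests on that limit: the limit of < 0.16 ug/mL in this assay, at which 1 of the 3 values shown sits.

The compounds shown leave open whether fluoro at this place moves the read-out at all, as compound 3 has no number to set beside that of compound 2. They also leave open what an amine or a carboxylic acid on the aromatic ring, or a longer chain in the alkyl part of the carbamate, would do to the read-out in this assay.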